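The source may hold more compounds than are shown below. What is called first, only, known or untested is meant among the compounds shown, and "the series" means these compounds.

Measured so far in a functional assay on HepG2 cells (Homo sapiens) for antiproliferative activity, read by CCK-8 assay, with a stated time of 72 h; a lower number here means a stronger inhibitor, a higher number a weaker inhibitor:
- compound 1 `Cc1ccc(C(=O)Nc2cccc(-c3oc4cc(-c5ccc(F)cc5)ccc4c(=O)c3O)c2)cc1` gives 2320 nM
- compound 2 `O=C(Nc1cccc(-c2oc3cc(-c4ccc(F)cc4)ccc3c(=O)c2O)c1)c1ccc(Br)cc1` gives 13900 nM
- compound 3 `COc1cc(OC)cc(C(=O)Nc2cccc(-c3oc4cc(-c5ccc(F)cc5)ccc4c(=O)c3O)c2)c1` gives 23500 nM

Compound 3 carries the highest number of the three. Its gap to compound 1 is real: a 10-fold higher number from compound 1 to compound 3 (1.01 log units; beyond the scatter). Its gap to compound 2 is not: a 1.7-fold higher number from compound 2 to compound 3 (0.23 log units; within the scatter), so compound 2 and compound 3 cannot be ordered against each other on these data.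

Compound 4 `O=C(Nc1cccc(-c2oc3cc(-c4ccc(F)cc4)ccc3c(=O)c2O)c1)c1cnc(Cl)nc1Cl` differs from compound 3 by 2,4-dichloropyrimidin-5-yl in place of 3,5-dimethoxyphenyl on a carbonyl carbon. The group on the carbonyl carbon is the only part of the series that has been varied, so all three measured steps bear on this change. Exchanging the whole aryl group gave a 10-fold higher number from compound 1 to compound 3 (1.01 log units; beyond the scatter) in one case and a 1.7-fold higher number from compound 2 to compound 3 (0.23 log units; within the scatter) in the other; a single substituent swap on that aryl group gave a 6.0-fold higher number from compound 1 to compound 2 (0.78 log units; beyond the scatter). For the measured compounds named here, none of the measured compounds carries a heteroaryl or a chlorine at this position, so the direction for compound 4 is open; the measured numbers all lie within the span between compound 1 and compound 3, and compound 3 already stands at its upper end. A step back toward the middle of that span is therefore expected, a 2.4-fold lower number from compound 3 to compound 4 (0.37 log units; beyond the scatter), though a result within the scatter of compound 3 would not surprise. For compound 4 in this assay the estimate is 10000 nM, with a range from 2500 nM to 40000 nM.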

Compound 4, half-maximal inhibitory concentration: > 100000 nM
Compound 4 was reported as a limit; the forecaster's own chance of this, stated with the estimate: 15%; middle value at least 10-fold (1.00 log units) away from the limit.
By their numbers in this assay, from the lowest: compound 1; then compounds 2 and 3 (each within the scatter of the next). At a limit, above all of these: compound 4.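

Compound 4 is reported in this assay only as a limit of the assay, not as a number: the limit of > 100000 nM in this assay, at which 1 of the 4 values shown sits. For the compounds shown here, the group on this carbonyl carbon had so far moved the number only within a measurable span, whereas the exchange for 2,4-dichloropyrimidin-5-yl takes the compound out of that span, with an at least 4.2-fold higher number from compound 3 to compound 4 (0.62 log units; beyond the scatter) and an at least 7.1-fold higher number from compound 2 to compound 4 (0.85 log units; beyond the scatter) and also an at least 43-fold higher number from compound 1 to compound 4 (1.63 log units; beyond the scatter) all resting on that limit. The three compounds with a six-membered aromatic ring of carbon only at this place all give numbers, while the single ring with hetero atoms gives none, which is one case and not yet a pattern.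

The 2,4-dichloropyrimidin-5-yl group brings ring nitrogens and chlorines together, so the compounds shown cannot tell which of the two goes with this result. A 2,4-dichlorophenyl group, an unsubstituted pyrimidin-5-yl group, or a pyrimidine carrying an amine in place of the chlorines would separate these parts of the change.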